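Sulfonyl Piperidine Replaces Aminopropoxy Chain on Shared Core

The compounds below may be only part of what the source reports. "The series", "measured", "known", "first", "only" and "open" are said of these compounds alone.

Compound 2 `O[C@H]1CC[C@H](NCCCOc2ccc([C@H]3CC[C@]4(CC3)OOC3(O4)C4CC5CC(C4)CC3C5)cc2)CC1` is measured in an ADME assay on microsomes from liver (Homo sapiens) for metabolic stability, read by LC-MS, tested at 1 uM (a higher number here means faster removal of the compound, a lower number slower removal), only as a limit, < 7 mL.min-1.g-1. Among the compounds with values here, compound 1 `OC1(COc2ccc([C@H]3CC[C@]4(CC3)OOC3(O4)C4CC5CC(C4)CC3C5)cc2)CCNCC1` gives 16 mL.min-1.g-1 in this assay, and the single measured step, an at least 2.2-fold lower number from compound 1 to compound 2 (0.35 log units; beyond the scatter), bears on the present change only through the shared core. Compound 2 rests at the limit of < 7 mL.min-1.g-1 in this assay, at which 1 of the 2 values shown sits. Compound 3 `NC1CCN(S(=O)(=O)c2ccc([C@H]3CC[C@]4(CC3)OOC3(O4)C4CC5CC(C4)CC3C5)cc2)CC1` brings the change ((4-aminopiperidin-1-yl)sulfonyl in place of 3-((4-hydroxycyclohexyl)amino)propoxy on an aromatic carbon). No measured step tests a sulfonyl or an aminopiperidine group, so the shown pairs give no direction beyond the scatter. Compound 3 is estimated at 8 mL.min-1.g-1 (range 3 mL.min-1.g-1 to 20 mL.min-1.g-1) in this assay, an expected step of an at least 1.1-fold higher number from compound 2 to compound 3 (0.05 log units; that floor lies within the scatter).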

Compound 3, intrinsic clearance in microsomes: < 7 mL.min-1.g-1
Compound 3: a limit, no number; the forecaster's own chance of this, stated with the estimate: 40%; at least 1.1-fold (0.05 log units) between middle value and limit.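

In this assay, (4-aminopiperidin-1-yl)sulfonyl in place of (4-hydroxypiperidin-4-yl)methoxy on the aromatic carbon gives an at least 2.2-fold lower number from compound 1 to compound 3 (0.35 log units; beyond the scatter), so a second, quite different group on this carbon also gives a lower number than compound 1, this time with a sulfonyl link and no ether chain. Compound 2 and compound 3 both read only as limits, and the step between them cannot be read: the limit of < 7 mL.min-1.g-1 in this assay, at which 2 of the 3 values shown sit.

Going by these compounds, it remains open how far under that limit either compound lies. On these data alone, it is also open whether a morpholine or a carboxylic acid in place of the amine on the sulfonyl piperidine would stay at the limit.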